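Chalcone-triazole conjugates: aryl variation on the enone

A few compounds are considered here, and "the series" means these few. Any claim that something is new, unique, unknown or untested is made for them only; others in the source may bear on it.

Measured so far:
compound 1 `COc1cccc(/C=C/C(=O)c2ccc(OCCn3cc(CN4C(=O)/C=C/C(C)(C)C/C=C(\C)CC/C=C/4C)nn3)cc2O)c1` — 0.95 ug/mL
compound 2 `COc1cc(/C=C/C(=O)c2ccc(OCCn3cc(CN4C(=O)/C=C/C(C)(C)C/C=C(\C)CC/C=C/4C)nn3)cc2O)cc(OC)c1OC` — 2.61 ug/mL

In a functional assay on SW480 cells (Homo sapiens) for antiproliferative activity (a higher number here means a weaker inhibitor, a lower number a stronger inhibitor), compound 2 stands at the higher of the two numbers; compound 1 sits lower, and the step of a 2.7-fold higher number from compound 1 to compound 2 (0.44 log units; beyond the scatter) lies beyond the scatter. Compound 3 `C/C1=C\CC(C)(C)/C=C/C(=O)N(Cc2cn(CCOc3ccc(C(=O)/C=C/c4ccc(C)cc4)c(O)c3)nn2)/C(C)=C/CC1` remains to be measured; it differs from compound 2 by 4-methylphenyl in place of 3,4,5-trimethoxyphenyl on a double-bonded chain carbon bound to a double-bonded chain carbon. Among the measured compounds shown here, only that single step bears on this change, and it moved modestly. The new aryl carries no acceptors, closer in that respect to compound 1, so the number is expected to fall back toward compound 1, giving a 2.0-fold lower number from compound 2 to compound 3 (0.30 log units; within the scatter). For compound 3 the estimate in this assay is 1.3 ug/mL, ranging from 0.5 ug/mL to 3.5 ug/mL.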

Compound 3, half-maximal inhibitory concentration: 1.16 ug/mL
Compound 3: middle estimate off by 1.1-fold (0.05 log units), on the high side, and the stated range covers the measured number.
By their numbers in this assay, from the lowest: compounds 1 and 3 (each within the scatter of the next); then compound 2.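

In this assay the step of a 2.3-fold lower number from compound 2 to compound 3 (0.35 log units; beyond the scatter) shows that the higher number of compound 2 is not shared by every replacement at this position. The step of a 1.2-fold higher number from compound 1 to compound 3 (0.09 log units; within the scatter) stays within the scatter, so 4-methylphenyl and 3-methoxyphenyl are not told apart here, and a methoxy group is not required for the lower numbers. No evidence is available on why the aryl change moves the number.

Still open, from the compounds shown here alone, is how an aryl carrying an amine or a carboxylic acid behaves at this place. Also open, going by these compounds, is whether two methoxy groups already raise the number.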